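A few compounds are considered here, and "the series" means these few. Any claim that something is new, unique, unknown or untested is made for them only; others in the source may bear on it.

Compound 1 `CC(=O)N[C@@H](CSC(=S)N[C@H]1CC[C@H](NC(=S)SC[C@H](NC(C)=O)C(=O)O)CC1)C(=O)O`: 3450 nM
Compound 2 `CCCCNC(=S)SC[C@H](NC(C)=O)C(=O)O`: 134000 nM
Compound 3 `S=C=Nc1cccc(N=C=S)c1`: 55700 nM

These three compounds were tested in a functional assay on LoVo/DX cells (Homo sapiens) for antiproliferative activity, read by sulforhodamine B assay, with a stated time of 72 h; on this read-out lower numbers stand for stronger inhibition and higher numbers for weaker inhibition. Compound 3, at 55700 nM, holds the second highest of the three numbers. It stands between compound 1, the lowest at 3450 nM, and compound 2, the highest at 134000 nM, and both gaps lie beyond the usual scatter.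

The next compound is compound 4 `Cc1ccc(N=C=S)cc1N=C=S`, which differs from compound 3 by a single change: methyl in place of hydrogen on an aromatic carbon. In words, this is a methyl in place of hydrogen on an aromatic carbon. Among the compounds with values here, the three measured compounds include no pair differing in one place, so the data offer no direct precedent for the size of this step. With so small a change, no step beyond the scatter is expected in this assay, and any shift could go in either direction.

The estimated change is a 1.1-fold lower number from compound 3 to compound 4 (0.05 log units; within the scatter). For compound 4, the expected value is 50000 nM, with an estimated range of 20000 nM to 120000 nM.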

Compound 4, half-maximal inhibitory concentration: 47300 nM
The estimate for compound 4 lay 1.1-fold (0.02 log units) above the measured number; the measured number falls inside the stated range.
By their numbers in this assay, from the lowest: compound 1; then compounds 4 and 3 (each within the scatter of the next); then compound 2.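

In this assay, within the data shown here, the first comparison in this set between compounds differing in one place gives a 1.2-fold lower number from compound 3 to compound 4 (0.07 log units; within the scatter) and so stays within the scatter. This shows that a methyl in place of hydrogen on this aromatic carbon, ortho to one group of 3 heavy atoms and para to another, produces no readable shift in either direction. Nothing available here gives a reason for this outcome.

Going by these compounds, whether a group other than methyl on the same carbon, such as an amine, a carboxylic acid or a longer chain, would also leave the number within the scatter remains open. On these data alone, it is equally open whether a methyl on another carbon of the six-membered aromatic ring would give the same result.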